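Hydroxy to 3-Aminopropyl on the Chain Carbon

The source may hold more compounds than are shown below. What is called first, only, known or untested is meant among the compounds shown, and "the series" means these compounds.

Compound 1 `O=C(CN(c1nc(Cl)nc2[nH]cnc12)C1CC1)N[C@@H](CO)C(=O)OCc1ccccc1` was tested in a functional assay on the whole organism (Tail, strain ICR) with Mus musculus as the target, in the tail flick test, with a stated time of 90 min, at a dose of 25 umol/kg by the oral route (a lower number here means a weaker effect, a higher number a stronger effect of the compound at the dose given), where compound 1 gives 34.5%. Among the compounds with values here, this is the lowest of the two numbers measured so far, but its only neighbour, compound 2 `O=C(CN(c1nc(Cl)nc2[nH]cnc12)C1CC1)N[C@@H](CO)C(=O)O`, gives 43.9% in this assay, and the step of a number 9.4 percentage points higher from compound 1 to compound 2 (within the scatter) lies within the scatter, so the two cannot be ranked. Compound 3 `NCCCC[C@H](NC(=O)CN(c1nc(Cl)nc2[nH]cnc12)C1CC1)C(=O)OCc1ccccc1` has not yet been measured. It differs from compound 1 in one place: 3-aminopropyl in place of hydroxy on a saturated chain carbon, two bonds along the chain from an amide-type nitrogen and a carbonyl carbon. Within the data shown here, the single measured step concerns the oxygen bearing the benzyl group, a different part of the molecule, and it was small; no measured step touches the chain carbon that carries the hydroxy. The data therefore give no ground for a step beyond the scatter in this assay in either direction. Compound 3 is accordingly expected to give about 36%, between 16% and 56%. The step so estimated, a number 1.5 percentage points higher from compound 1 to compound 3 (within the scatter), is expected to stay within the scatter.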

Compound 3, a percentage reported as activity, at one dose (the size of the read-out at that dose, not a potency): 35.3%
For compound 3 the middle estimate is 0.7 percentage points above the measured one, within the range that was stated.
By their numbers in this assay, from the lowest: compounds 1, 3 and 2 (each within the scatter of the next).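

Within the data shown here, this is the first measured step at the chain carbon that carries the hydroxy: 3-aminopropyl in place of hydroxy, on a saturated chain carbon, two bonds along the chain from an amide-type nitrogen and a carbonyl carbon, gives in this assay a number 0.8 percentage points higher from compound 1 to compound 3 (within the scatter). The heavy atoms of the group go from 1 to 4, and the hydroxy is replaced by an amine-bearing chain, yet the step stays inside the scatter, so this pair gives no sign that the read-out depends on this group. No evidence on the cause of this result is available.

The compounds shown leave open how a methyl group or a phenyl ring on this chain carbon would read in this assay. They also leave open whether hydrogen in place of benzyl gives a step of like size with 3-aminopropyl present.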